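The source may hold more compounds than are shown below. What is called first, only, known or untested is meant among the compounds shown, and "the series" means these compounds.

Of the compounds shown here, three built on one shared core have been tested in a functional assay on EC9706 cells (Homo sapiens) for antiproliferative activity, read by MTT assay, with a stated time of 72 h; a lower number here means a stronger inhibitor, a higher number a weaker inhibitor. For compound 1 `C/C(=N\NC(=O)c1cccc(S(=O)(=O)N2CCOCC2)c1)c1ccc(F)cc1` the result is not a number but a limit of the assay, > 100000 nM, and this is the only such limit among the three results (the limit of > 100000 nM in this assay, at which 1 of the 3 values shown sits). Compound 2 `C/C(=N\NC(=O)c1cccc(S(=O)(=O)N2CCOCC2)c1)c1ccccc1O` gives 1220 nM in this assay, while compound 3 `C/C(=N\NC(=O)c1cccc(S(=O)(=O)N2CCOCC2)c1)c1cc(F)ccc1O` gives 2210 nM. The swap of the aryl group brought an at least 81-fold lower number from compound 1 to compound 2 (1.91 log units; beyond the scatter) and, in the fluorinated case, an at least 45-fold lower number from compound 1 to compound 3 (1.65 log units; beyond the scatter). Within the hydroxyphenyl pair, a 1.8-fold higher number from compound 2 to compound 3 (0.26 log units; within the scatter), so compound 2 and compound 3 cannot be told apart on these numbers.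

Compound 4 `C/C(=N\NC(=O)c1cccc(S(=O)(=O)N2CCOCC2)c1)c1cccc(N)c1O` differs from compound 2 by amino in place of hydrogen on an aromatic carbon. For the measured compounds named here, the only measured step that touches the same ring, a 1.8-fold higher number from compound 2 to compound 3 (0.26 log units; within the scatter), stayed inside the scatter, so a further small substituent there is expected to give a 1.2-fold higher number from compound 2 to compound 4 (0.09 log units; within the scatter). On that basis compound 4 is estimated at 1500 nM in this assay, with a likely range from 500 nM to 5000 nM.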

Compound 4, half-maximal inhibitory concentration: 3520 nM
Beside the measured number, compound 4's estimate is 2.3-fold (0.37 log units) below it; measured number inside the range.
By their numbers in this assay, from the lowest: compounds 2, 3 and 4 (each within the scatter of the next, the first and the last beyond it). At a limit, above all of these: compound 1.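

Amino on this ring carbon, ortho to a hydroxy group, is the first change to the 2-hydroxyphenyl ring that moves the number beyond the scatter in this assay (a 2.9-fold higher number from compound 2 to compound 4 (0.46 log units; beyond the scatter)), a modest step towards a weaker inhibitor. Compound 4 cannot be told apart from the fluorinated compound (a 1.6-fold higher number from compound 3 to compound 4 (0.20 log units; within the scatter)), yet the 3-amino-2-hydroxyphenyl group still stands well clear of the 4-fluorophenyl group (an at least 28-fold lower number from compound 1 to compound 4 (1.45 log units; beyond the scatter)). That last step is only a bound, because compound 1 stands at a limit of the assay: the limit of > 100000 nM in this assay, at which 1 of the 4 values shown sits.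

As far as these compounds go, whether this rise belongs to the amino group itself or would follow any group here stays open; a methoxy, a chloro or a dimethylamino group at the same carbon would help to tell. From the compounds shown here alone, how amino behaves elsewhere on the ring also stays open.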